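Hydrazone chain extension on the nitrophenylthiazole core

The source may report more compounds than this note shows. Statements on the series, on what has been measured and on what is new or still open speak of the compounds shown alone.

Compound 3 `CCC(CC)=NNc1nc(-c2cccc([N+](=O)[O-])c2)cs1` gives 24300 nM in an assay on isolated protein for inhibition of Amine oxidase [flavin-containing] A (Homo sapiens), read by fluorescence, with a stated time of 20 min (on this read-out lower numbers stand for stronger inhibition and higher numbers for weaker inhibition), and stands second highest of the three measured numbers. Its nearest neighbour is compound 1 `CC/C(C)=N\Nc1nc(-c2cccc([N+](=O)[O-])c2)cs1`, which gives 20500 nM; compound 2 `CCC/C(C)=N\Nc1nc(-c2cccc([N+](=O)[O-])c2)cs1` gives 38000 nM. The step of a 1.2-fold higher number from compound 1 to compound 3 (0.07 log units; within the scatter) and the step of a 1.6-fold lower number from compound 2 to compound 3 (0.19 log units; within the scatter) both sit inside the scatter. Compound 4 `CCC/C(CC)=N\Nc1nc(-c2cccc([N+](=O)[O-])c2)cs1` carries methyl in place of hydrogen on a saturated chain carbon, two bonds along the chain from a carbon with a double bond to nitrogen relative to compound 3. The same change, taken on compound 1, is the step of a 1.9-fold higher number from compound 1 to compound 2 (0.27 log units; within the scatter), so a step of at most that size toward a higher number is expected here, or none beyond the scatter. The step from compound 3 to compound 4 is therefore estimated as a 1.4-fold higher number from compound 3 to compound 4 (0.16 log units; within the scatter). For compound 4 the expected value in this assay is 35000 nM, with a range from 15000 nM to 80000 nM.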

Compound 4, half-maximal inhibitory concentration: 4860 nM
For compound 4 the middle estimate is 7.2-fold (0.86 log units) above the measured one; the measured number lies below the stated range.
By their numbers in this assay, from the lowest: compound 4; then compounds 1, 3 and 2 (each within the scatter of the next).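

At this position the methyl change does not carry over from one parent to another: the same change on two cores in this assay, a 1.9-fold higher number (0.27 log units; within the scatter) from compound 1 to compound 2 and a 5.0-fold lower number (0.70 log units; beyond the scatter) from compound 3 to compound 4, 9.3-fold (0.97 log units) apart, beyond the scatter of two such steps

Among these compounds, compound 4 is the only compound that separates beyond the scatter from all the others, with a 5.0-fold lower number from compound 3 to compound 4 (0.70 log units; beyond the scatter), a 7.8-fold lower number from compound 2 to compound 4 (0.89 log units; beyond the scatter) and a 4.2-fold lower number from compound 1 to compound 4 (0.63 log units; beyond the scatter). Compounds 1, 2 and 3 remain unresolved from one another, so the lower number appears only with the largest chain shown.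

From the compounds shown here alone, whether a longer chain lowers the number further or reverses the step remains open. Also open, going by these compounds, is whether the step survives with an amine in place of the nitro group.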